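Amino to dimethylamino in the series

The source may hold more compounds than are shown below. What is called first, only, known or untested is meant among the compounds shown, and "the series" means these compounds.

In a functional assay on HCT-8 cells (Homo sapiens) for antiproliferative activity, read by MTT assay, with a stated time of 48 h (a higher number here means a weaker inhibitor, a lower number a stronger inhibitor), compound 2 `COc1ccc(C(=O)c2ccc(OC)c3c2OC(C)(C)C=C3)c(NC(=O)CN)c1` gives 370 nM. That value lies within the scatter of compound 1 `COc1ccc(C(=O)c2ccc(OC)c3c2OC(C)(C)C=C3)c(NC(=O)CO)c1` at 230 nM, and both sit well under compound 3 `CNCC(=O)Nc1cc(OC)ccc1C(=O)c1ccc(OC)c2c1C=CC(C)(C)O2` at 3460 nM. Compound 4 `COc1ccc(C(=O)c2ccc(OC)c3c2OC(C)(C)C=C3)c(NC(=O)CN(C)C)c1` is still unmeasured. It carries dimethylamino in place of amino on a saturated chain carbon bound to a carbonyl carbon.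

For the measured compounds named here, only one measured step touches this place, the change from hydroxy to amino, a 1.6-fold higher number from compound 1 to compound 2 (0.21 log units; within the scatter). That step is small and within the scatter, so the series shows little response here so far, though on a single pair. Going by the values given here, compound 3 differs from compound 2 in more than one place and gives no clean step, but its higher number argues for keeping the upper range wide. No change beyond the scatter is expected, with a slight lean toward a higher number. The expected step is a 1.4-fold higher number from compound 2 to compound 4 (0.13 log units; within the scatter). For compound 4 the estimate is 500 nM, with an expected range of 150 nM to 2000 nM.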

Compound 4, half-maximal inhibitory concentration: 1590 nM
The estimate for compound 4 lay 3.2-fold (0.50 log units) below the measured number, within the range that was stated.
By their numbers in this assay, from the lowest: compounds 1 and 2 (each within the scatter of the next); then compound 4; then compound 3.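

In this assay this position proves responsive: a 4.3-fold higher number from compound 2 to compound 4 (0.63 log units; beyond the scatter), whereas the earlier change from hydroxy to amino stayed within the scatter. Dimethylamino also stands apart from hydroxy, with a 6.9-fold higher number from compound 1 to compound 4 (0.84 log units; beyond the scatter), so compound 1 and compound 2 share a level that compound 4 does not reach, and the series no longer looks indifferent to what sits on this saturated chain carbon bound to a carbonyl carbon. No measurement shown here accounts for this step, so only its size is on record.

Open, on these data alone, is whether diethylamino or a ring amine such as pyrrolidin-1-yl on this chain carbon would give a number higher still than that of compound 4. Also open, as far as these compounds go, is whether a carboxylic acid here would stay level with compound 1 and compound 2.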